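The source may report more compounds than this note shows. Statements on the series, on what has been measured and on what is new or still open speak of the compounds shown alone.

Measured so far in a functional assay on HCT-116 cells (Homo sapiens) for antiproliferative activity, read by MTT assay, with a stated time of 72 h; a lower number here means a stronger inhibitor, a higher number a weaker inhibitor:
compound 1 `CN(C(=O)c1ccc(F)cc1)c1ccc2[nH]c(-c3n[nH]c4ccccc34)cc2n1` gives 9270 nM
compound 2 `CN(C(=O)c1ccc(Br)cc1)c1ccc2[nH]c(-c3n[nH]c4ccccc34)cc2n1` gives 6110 nM
compound 3 `CN(C(=O)c1ccccc1)c1ccc2[nH]c(-c3n[nH]c4cc(Cl)ccc34)cc2n1` gives 13100 nM

All three compounds share one core and differ only in small groups on its edges. Going by the values given here, the three numbers sit close together: the value of compound 1 and the value of compound 3 lie within the usual scatter of each other, and the one measured step, a 1.5-fold lower number from compound 1 to compound 2 (0.18 log units; within the scatter), stays within the scatter as well. Compound 1 therefore stands among three numbers that cannot be told apart with confidence.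

Compound 4 `CN(c1ccc2[nH]c(-c3n[nH]c4ccccc34)cc2n1)S(=O)(=O)c1ccc(Cl)cc1` has not been measured. It differs from compound 1 in one place: (4-chlorophenyl)sulfonyl in place of (4-fluorophenyl)carbonyl on a nitrogen on an aromatic ring. Among the compounds with values here, only one measured step bears on this change. It swaps one halogen for another on the same phenyl ring, a 1.5-fold lower number from compound 1 to compound 2 (0.18 log units; within the scatter), and is within the scatter, which suggests the chloro in compound 4 matters little by itself. Within the data shown here, the exchange of a carbonyl for a sulfonyl has no measured counterpart here, so that part of the change carries real uncertainty. The expectation is a step from compound 1 to compound 4 of a 1.0-fold lower number from compound 1 to compound 4 (0.01 log units; within the scatter) in this assay, meaning none beyond the scatter. Compound 4 is therefore estimated at 9000 nM, with a range from 3000 nM to 30000 nM.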

Compound 4, half-maximal inhibitory concentration: 5980 nM
The estimate for compound 4 lay 1.5-fold (0.18 log units) above the measured number; low and high end bracket the measured number.
By their numbers in this assay, from the lowest: compounds 4, 2, 1 and 3 (each within the scatter of the next, the first and the last beyond it).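

The earlier compounds shown here tested only a swap of one halogen for another on the phenyl ring, whereas compound 4 changes the link itself on a nitrogen on an aromatic ring, and in this assay the result is a 1.6-fold lower number from compound 1 to compound 4 (0.19 log units; within the scatter) for this exchange of (4-fluorophenyl)carbonyl for (4-chlorophenyl)sulfonyl. Measured against the bromo compound, the exchange gives a 1.0-fold lower number from compound 2 to compound 4 (0.01 log units; within the scatter) and so also stays small, which shows that in these two pairs this position accepts a sulfonyl as well as a carbonyl with no change that can be told from the scatter. No measurement is at hand that could explain this similarity.

Going by these compounds, the chloro and the sulfonyl enter together in compound 4, and the separate contribution of each remains open. Also open, on these data alone, is whether an amine or a carboxylic acid on the phenyl ring, or a longer chain in place of the saturated chain carbon on the same nitrogen, would move the number beyond the scatter.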